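This account rests on a few compounds, and the source may have more. Where it says the series, first, only, none or still open, it means among the compounds named here.

Compound 1 `COc1ccc(-c2ccc(COCCCCCN3C[C@H](O)[C@@H](O)[C@H](O)[C@H]3CO)cc2)cc1` gives 25 nM in an assay on isolated protein for inhibition of ceramide glucosyltransferase (Homo sapiens); on this read-out higher numbers stand for weaker inhibition and lower numbers for stronger inhibition.
Compound 2 `COc1cccc(-c2ccc(COCCCCCN3C[C@H](O)[C@@H](O)[C@H](O)[C@H]3CO)cc2)c1` gives 150 nM in this assay.
Compound 3 `OC[C@@H]1[C@@H](O)[C@H](O)[C@@H](O)CN1CCCCCOCc1ccc(-c2ccccc2F)cc1` gives 75 nM in this assay.

All three share the same core and differ only in the group attached to the outer aromatic ring. On these numbers compound 3 stands second highest of the three: its value and that of compound 2 lie within the usual scatter of this assay, so no order between them can be claimed, whereas compound 1 stands clearly lower, with a 3.0-fold higher number from compound 1 to compound 3 (0.48 log units; beyond the scatter). The next step leads to the unmeasured compound 4 `OC[C@@H]1[C@@H](O)[C@H](O)[C@@H](O)CN1CCCCCOCc1ccc(-c2ccc3c(c2)OCCO3)cc1`, and the change is 2,3-dihydro-1,4-benzodioxin-6-yl in place of 2-fluorophenyl on an aromatic carbon. Within the data shown here, two measured steps bear on it: a 3.0-fold higher number from compound 1 to compound 3 (0.48 log units; beyond the scatter), a modest rise when 2-fluorophenyl replaced 4-methoxyphenyl, and a 2.0-fold lower number from compound 2 to compound 3 (0.30 log units; within the scatter), which stayed within the scatter. Compound 4 restores oxygen to the outer ring, as in compound 1, which gives 25 nM. A modest step back toward that lower number is therefore expected for compound 4, a 1.9-fold lower number from compound 3 to compound 4 (0.27 log units; within the scatter). Compound 4 is estimated at 40 nM, within 15 nM to 120 nM.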

Compound 4, half-maximal inhibitory concentration: 40 nM
For compound 4 middle estimate and measured number coincide at the digits printed; low and high end bracket the measured number.
By their numbers in this assay, from the lowest: compounds 1, 4, 3 and 2 (each within the scatter of the next, the first and the last beyond it).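

Among these compounds, the 2,3-dihydro-1,4-benzodioxin-6-yl group is the first outer ring here with its oxygen atoms held in a second ring, and it brings a larger group with two hydrogen-bond acceptors to this position. Even so, there is a 1.9-fold lower number from compound 3 to compound 4 (0.27 log units; within the scatter) and a 1.6-fold higher number from compound 1 to compound 4 (0.20 log units; within the scatter), both within the scatter, so this group cannot be separated from 2-fluorophenyl or 4-methoxyphenyl, while a 3.8-fold lower number from compound 2 to compound 4 (0.57 log units; beyond the scatter) does set it apart from 3-methoxyphenyl. Nothing measured here explains these differences.

Going by these compounds, whether the closed ring itself matters stays open, and a comparison with an outer ring carrying two separate methoxy groups would address that. On these data alone, how an amine or a carboxylic acid on the outer ring would behave at this position also remains unknown.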